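The source may hold more compounds than are shown below. What is called first, only, known or untested is meant among the compounds shown, and "the series" means these compounds.

Working notes on the carbamate series, followed in an ADME assay on Vero C1008 cells (Chlorocebus sabaeus) for cytotoxicity, read by luminescence and CellTiter-Glo, with a stated time of 24 h; on this read-out lower numbers stand for higher toxicity in this test and higher numbers for lower toxicity in this test. Compound 1 `CC(C)C[C@H](NC(=O)OCCc1cccc(Cl)c1)C(=O)N[C@H](C=O)C[C@@H]1CCNC1=O` gives only a limit of the assay, > 200000 nM. Compound 2 `CC(C)C[C@H](NC(=O)O[C@@H](C)c1ccccc1)C(=O)N[C@H](C=O)C[C@@H]1CCNC1=O` likewise gives only a limit, > 200000 nM. The step that the two limits leave unreadable from compound 1 to compound 2 is therefore unreadable. Compound 2 stands at the same limit as compound 1, since (the limit of > 200000 nM in this assay, at which 2 of the 2 values shown sit). Compound 3 `CC(C)C[C@H](NC(=O)O[C@H](C)c1ccccc1)C(=O)N[C@H](C=O)C[C@@H]1CCNC1=O` differs from compound 2 only in configuration: the two compounds have the same atoms and bonds and differ only in configuration as drawn: 1 of 4 stereo elements differ; a stereocentre at a saturated chain carbon is drawn S in compound 2 and R in compound 3. No measured step bears on such an inversion, the single step shown being unreadable. Compound 3 is expected to sit at the limit as well, with an estimated value of 200000 nM, between 100000 nM and 400000 nM. The step of a number no higher from compound 2 to compound 3 (the limit leaves the size open) is accordingly expected to be none beyond the scatter.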

Compound 3, half-maximal cytotoxic concentration: > 200000 nM
Compound 3 gave a limit, no number; the forecaster's own chance of this, stated with the estimate: 85%; the middle value lies on the limit itself.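

In this assay compound 3 gives only a limit, > 200000 nM. The steps to compound 3 from compound 1 and compound 2 therefore cannot be read. Still open, as far as these compounds go, is where any of these three compounds lies beyond the limit, and whether the configuration at the saturated chain carbon matters there.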